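From dichlorophenyl to methoxyphenyl: estimating compound 3

The compounds below may be only part of what the source reports. "The series", "measured", "known", "first", "only" and "open" are said of these compounds alone.

Measured so far:
- Compound 1 `COc1ccc(/C=C/C(=O)c2c(OC)cc(OC)cc2OCC=C(C)C)cc1` gives 7600 nM
- Compound 2 `COc1cc(OC)c(C(=O)/C=C/c2cccc(Cl)c2Cl)c(OCC=C(C)C)c1` gives 1900 nM

In a functional assay on HCT-116 cells (Homo sapiens) for antiproliferative activity, read by sulforhodamine B assay, with a stated time of 48 h (on this read-out higher numbers stand for weaker inhibition and lower numbers for stronger inhibition), compound 2 gives 1900 nM as the lower of the two numbers, so it is the stronger inhibitor of this pair. The next compound, compound 3 `COc1cccc(/C=C/C(=O)c2c(OC)cc(OC)cc2OCC=C(C)C)c1`, keeps the shared core and changes one group: 3-methoxyphenyl in place of 2,3-dichlorophenyl on a double-bonded chain carbon bound to a double-bonded chain carbon is the whole difference.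

Within the data shown here, only one measured step bears on this change. It is a 4.0-fold lower number from compound 1 to compound 2 (0.60 log units; beyond the scatter) and came from putting 2,3-dichlorophenyl in place of 4-methoxyphenyl. Among the measured compounds shown here, compound 3 returns to a methoxyphenyl group, so the swap may undo much of that step, though no measured compound carries 3-methoxyphenyl itself. Compound 1, the methoxyphenyl example, gives 7600 nM as the best guide to where this could lead. The expected move is a 2.5-fold higher number from compound 2 to compound 3 (0.40 log units; beyond the scatter) toward weaker inhibition, probably somewhat smaller than the measured step. Compound 3 is estimated at 4800 nM with an expected range from 1900 nM to 12000 nM in this assay as the working forecast.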

Compound 3, half-maximal inhibitory concentration: 7700 nM
Beside the measured number, compound 3's estimate is 1.6-fold (0.21 log units) below it; low and high end bracket the measured number.
By their numbers in this assay, from the lowest: compound 2; then compounds 1 and 3 (each within the scatter of the next).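

In this assay, putting 3-methoxyphenyl in place of 2,3-dichlorophenyl gives a 4.1-fold higher number from compound 2 to compound 3 (0.61 log units; beyond the scatter) and this shows that compound 2 keeps the lowest number of the three compounds, now against two methoxyphenyl partners rather than one. Putting 3-methoxyphenyl in place of 4-methoxyphenyl gives a 1.0-fold higher number from compound 1 to compound 3 (0.01 log units; within the scatter) and so, on this shared core, these two methoxyphenyl groups cannot be told apart by their numbers. The gap at this position therefore separates 2,3-dichlorophenyl from both methoxyphenyl groups, while moving the methoxy group between these two ring placements leaves no readable trace, and no measurement here explains why the dichlorophenyl group stands apart.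

These three compounds leave open whether both chlorines are needed or whether a ring carrying only one chlorine would give a similar number. They also cannot say what a plain phenyl ring, or a ring carrying an amine or a carboxylic acid, would do at this place on the shared core.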